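Pyrazole amide series: aryl versus isopropyl on the ring carbon

The compounds below may be only part of what the source reports. "The series", "measured", "known", "first", "only" and "open" are said of these compounds alone.

Measured so far in an assay on isolated protein for antagonist activity at Bile acid receptor (Homo sapiens), read by TR-FRET, with a stated time of 20 min; on this read-out lower numbers stand for stronger inhibition and higher numbers for weaker inhibition:
compound 1 `Cc1ccc(-c2nn(CC3CC3)cc2C(=O)Nc2ccc(C)c(S(=O)(=O)N3CCOCC3)c2)cc1` gives 76.9 nM
compound 2 `Cc1ccc(-c2nn(CCCCO)cc2C(=O)Nc2ccc(C)c(S(=O)(=O)N3CCOCC3)c2)cc1` gives 130 nM
compound 3 `COc1cccc(Cn2cc(C(=O)Nc3ccc(C)c(S(=O)(=O)N4CCOCC4)c3)c(C(C)C)n2)c1` gives 199 nM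

Compound 3 has the highest number of the three in this assay; against compound 2 the gap is within the scatter, against compound 1 it is beyond it.

Compound 4 `COc1cccc(Cn2cc(C(=O)Nc3ccc(C)c(S(=O)(=O)N4CCOCC4)c3)c(-c3cccc(OC)c3)n2)c1` differs from compound 3 by 3-methoxyphenyl in place of isopropyl on an aromatic carbon. Among the compounds with values here, the only measured step, a 1.7-fold higher number from compound 1 to compound 2 (0.23 log units; within the scatter), concerns the chain on the aromatic nitrogen, not this carbon, so no step bears on the change directly. Compounds 1 and 2, which carry an aromatic ring rather than isopropyl on that carbon, show lower numbers than compound 3. A modest improvement is therefore expected, a 1.8-fold lower number from compound 3 to compound 4 (0.26 log units; within the scatter), giving an estimate for compound 4 of 110 nM with a range of 50 nM to 250 nM.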

Compound 4, half-maximal inhibitory concentration: 42.8 nM
Compound 4: middle estimate off by 2.6-fold (0.41 log units), on the high side; measured number outside the range, below it.
By their numbers in this assay, from the lowest: compounds 4, 1, 2 and 3 (each within the scatter of the next, the first and the last beyond it).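

In this assay, within the data shown here, the substituent on the aromatic carbon next to the ring nitrogen matters: 3-methoxyphenyl in place of isopropyl gives a 4.6-fold lower number from compound 3 to compound 4 (0.67 log units; beyond the scatter) and so is the first step beyond the scatter. Among these compounds, the only earlier step, a 1.7-fold higher number from compound 1 to compound 2 (0.23 log units; within the scatter) on the chain at the aromatic nitrogen, stays within it.

Open, going by these compounds, is whether a phenyl ring carrying an amine or a carboxylic acid at this carbon keeps the number of compound 4, and whether the same swap holds with other chains on the ring nitrogen. No measurement to hand accounts for the size of this step.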